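Sulfonamide aryl variation in the shared core

This account rests on a few compounds, and the source may have more. Where it says the series, first, only, none or still open, it means among the compounds named here.

Two compounds of the series carry the same core and differ only in the aryl group on the sulfonyl sulfur. In an assay on MDA-MB-231 cells for binding affinity to C-X-C chemokine receptor type 4 (Homo sapiens), read by fluorescence and microscopy, with stated times of 10 min and 30 min (on this read-out higher numbers stand for an effect only at larger amounts of compound and lower numbers for an effect already at smaller amounts), compound 1 `O=C(NCc1ccc(CNS(=O)(=O)c2ccc(CN3CCCC3)cc2)cc1)c1ccc(F)cc1` gives 1 nM, while compound 2 `O=C(NCc1ccc(CNS(=O)(=O)c2ccccc2F)cc1)c1ccc(F)cc1` gives 10 nM, the higher of the two numbers, and the gap between them lies beyond the scatter. Compound 3 `O=C(NCc1ccc(CNS(=O)(=O)c2ccc(F)c(F)c2)cc1)c1ccc(F)cc1` has not been measured; it differs from compound 2 by 3,4-difluorophenyl in place of 2-fluorophenyl on a sulfonyl sulfur. Among the compounds with values here, no measured step of this kind is available, so the expected step from compound 2 to compound 3 is a 1.3-fold lower number from compound 2 to compound 3 (0.10 log units; within the scatter), a small move toward a lower number that may not exceed the scatter. Compound 3 is accordingly estimated at 8 nM, within the range 2 nM to 30 nM.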

Compound 3, effective concentration (reported as EC, without a stated level of effect): 10 nM
Estimate against measurement, compound 3: 1.3-fold (0.10 log units) below; low and high end bracket the measured number.
By their numbers in this assay, from the lowest: compound 1; then compounds 2 and 3 (each within the scatter of the next).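

Among these fluorinated aryl groups on the sulfonyl sulfur, 3,4-difluorophenyl in place of 2-fluorophenyl gives no change at the digits printed from compound 2 to compound 3 (within the scatter) in this assay, so the added fluorine leaves the reading unmoved. Neither fluorinated compound reaches the lowest number in the set, held by compound 1 at 1 nM. No available evidence bears on this result. Open, as far as these compounds go, is whether an aryl group carrying a dimethylaminomethyl group or a carboxylic acid would read like compound 1 or like compound 2 and compound 3.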